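Cytotoxicity Limits Along One Series of Four Compounds

This account rests on a few compounds, and the source may have more. Where it says the series, first, only, none or still open, it means among the compounds named here.

Compound 1 `CC(C)N(Cc1cccc(OCCCCCC(=O)O)c1)C(=O)c1ccccc1` gives, as a limit of the assay, > 26000 nM in an ADME assay on HepG2 cells (Homo sapiens) for cytotoxicity, read by CellTiter-Glo and resazurin assay, with a stated time of 72 h; a higher number here means that more compound is needed for the effect, a lower number that less compound is needed.
Compound 2 `CC(C)N(Cc1cccc(OCCCCCC(=O)O)c1)C(=O)c1ccc(-c2ccncc2)cc1` gives, as a limit, > 26000 nM in this assay.
Compound 3 `CC(C)COc1cccc(-c2ccc(C(=O)N(Cc3cccc(OCCCCCC(=O)O)c3)C(C)C)cc2)c1` gives, as a limit, > 26000 nM in this assay.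

Compound 1 therefore stands at the limit of > 26000 nM in this assay, at which 3 of the 3 values shown sit, and no number for it is known, only that it lies past the limit. Compound 4 `COc1cc(F)cc(-c2ccc(C(=O)N(Cc3cccc(OCCCCCC(=O)O)c3)C(C)C)cc2)c1` is the unmeasured member of the series. It differs from compound 1 in one place: 3-fluoro-5-methoxyphenyl in place of hydrogen on an aromatic carbon.

Within the data shown here, two measured steps bear on this change, since each adds a ring at the same place on compound 1. Both were a step that the two limits leave unreadable from compound 1 to compound 2 and a step that the two limits leave unreadable from compound 1 to compound 3, so neither tells how far any compound lies beyond the limit, and the third comparison, a step that the two limits leave unreadable from compound 2 to compound 3, is equally unreadable. Among the measured compounds shown here, there is thus no measured step that shows any change in this assay beyond the scatter when this position is substituted.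

The expectation is that compound 4 will behave in the same way, a step that the limit leaves unreadable from compound 1 to compound 4 that is not read as a number. The estimate for compound 4 is 40000 nM, with a range from 20000 nM to 120000 nM, most likely again reported only as a limit.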

Compound 4, half-maximal effective concentration: > 26000 nM
Compound 4: a limit, no number; the forecaster's own chance of this, stated with the estimate: 85%; the middle value does not contradict the limit.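

In this assay compound 4 gives > 26000 nM, which is a limit and not a number. Among these compounds, no step from compound 1, compound 2 or compound 3 to compound 4 can be read, and the four compounds share one result: the limit of > 26000 nM in this assay, at which 4 of the 4 values shown sit. The compounds shown leave open how far any of them lies past the limit, and whether any ring added at this place changes the result in this assay at all.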